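Series notes: methyl for fluoro on the benzylsulfanyl ring

The source may report more compounds than this note shows. Statements on the series, on what has been measured and on what is new or still open speak of the compounds shown alone.

Compound 2 `O=C(O)c1ccc(C(=O)/C(=C\c2ccc(F)c([N+](=O)[O-])c2)SCc2ccc(F)cc2)cc1` in a functional assay on DU-145 cells (Homo sapiens) for inhibition, read by trypan blue exclusion, with a stated time of 96 h (on this read-out lower numbers stand for stronger inhibition of growth and higher numbers for weaker inhibition of growth), gives 1000 nM. Compound 1 `O=C(/C(=C\c1ccc(F)c([N+](=O)[O-])c1)SCc1ccc(F)cc1)c1ccc(F)cc1` gives 1000 nM, and the step of no change at the digits printed from compound 1 to compound 2 (within the scatter) shows that the carboxy in place of fluoro on an aromatic carbon left the number where it was. Compound 3 `Cc1ccc(CS/C(=C/c2ccc(C(=O)O)cc2)C(=O)c2ccc(Cl)c([N+](=O)[O-])c2)cc1` gives 10000 nM, so compound 2 stands level with compound 1 and together they are the lowest of the three numbers, with compound 3 sitting a clear step higher.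

Compound 4 `Cc1ccc(CS/C(=C/c2ccc(F)c([N+](=O)[O-])c2)C(=O)c2ccc(C(=O)O)cc2)cc1` differs from compound 2 by methyl in place of fluoro on an aromatic carbon. Within the data shown here, no measured step covers this change: the one step recorded, from compound 1 to compound 2, concerns a different ring and was flat. Compound 3 carries the methylbenzyl group but also differs in other places, so its value alone cannot be assigned to that group. The step is therefore expected to be small, no change at the digits printed from compound 2 to compound 4 (within the scatter), with no direction beyond the scatter. Compound 4 is estimated at 1000 nM, within 400 nM to 3000 nM.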

Compound 4, concentration for 50% growth inhibition: 1000 nM
Estimate against measurement, compound 4: no gap at the digits printed; measured number inside the range.
By their numbers in this assay, from the lowest: compounds 1, 2 and 4 (each within the scatter of the next); then compound 3.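

Among these compounds, the change from (4-fluorobenzyl)sulfanyl to (4-methylbenzyl)sulfanyl gives no change at the digits printed from compound 2 to compound 4 (within the scatter) in this assay, and this is the first reading at this position. With the carboxy group held in place, methyl and fluoro on this aromatic carbon cannot be told apart in this read-out, so the flat result now covers two separate positions, the earlier one being the carboxy for fluoro step. Nothing available explains why the two groups read alike.

As far as these compounds go, whether the position stays flat with a different kind of group, such as an amine, a methoxy group or a longer chain, remains open. Also open, from the compounds shown here alone, is whether the methyl change reads the same without the carboxy group, as in the core of compound 1, and the higher number of compound 3 still cannot be traced to a single change.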